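The compounds below may be only part of what the source reports. "The series", "measured", "known", "first", "only" and "open" are said of these compounds alone.

Of the compounds shown here, two with a shared core have been tested so far. In a functional assay on SK-HEP1 cells (Homo sapiens) for cytotoxicity, read by MTT assay, with a stated time of 48 h (a lower number here means a stronger inhibitor, a higher number a weaker inhibitor), compound 1, `Cc1cnc(N2C(=O)c3ccccc3C2=O)s1`, gives no number but only the limit of the measurement, > 200000 nM. Compound 2, `Cc1ccc2c(c1)C(=O)N(c1nccs1)C2=O`, likewise reaches only the limit in this assay, namely > 200000 nM. Compound 2 thus stands at the limit of > 200000 nM in this assay, at which 2 of the 2 values shown sit. Compound 3, `O=C1c2ccccc2C(=O)N1c1nccs1`, differs from compound 2 by hydrogen in place of methyl on an aromatic carbon. For this small change no shift beyond the usual scatter is expected in this assay. The expected step is a step that the limit leaves unreadable from compound 2 to compound 3. Compound 3 is therefore estimated at 300000 nM, most likely between 60000 nM and 2000000 nM.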

Compound 3, half-maximal inhibitory concentration: > 200000 nM
Compound 3 was reported as a limit; the forecaster's own chance of this, stated with the estimate: 85%; the middle value is on the limit's open side.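

In this assay, for the compounds shown here, compound 3 gives only a limit, > 200000 nM, so no step from compound 1 or compound 2 to compound 3 can be read. The compounds shown leave open whether methyl or hydrogen on the shared core makes any difference, since all of them stop at the same point: the limit of > 200000 nM in this assay, at which 3 of the 3 values shown sit.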